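A few compounds are considered here, and "the series" means these few. Any claim that something is new, unique, unknown or untested is made for them only; others in the source may bear on it.

Measured compounds:

Compound 1 `Oc1ccc(-c2nc3cc(C(F)(F)F)ccc3[nH]2)cc1` gives 17000 nM in an ADME assay on MT4 cells (Homo sapiens) for cytotoxicity, read by MTT assay, with a stated time of 96 h; on this read-out lower numbers stand for higher toxicity in this test and higher numbers for lower toxicity in this test.
Compound 2 `Oc1ccc(-c2nc3cc(Cl)c(Cl)cc3[nH]2)cc1` gives 12000 nM in this assay.
Compound 3 `O=[N+]([O-])c1ccc(-c2nc3cc(C(F)(F)F)ccc3[nH]2)cc1` gives 6000 nM in this assay.

All three compounds share the same general build: a phenyl ring carrying one small group, attached to a second, fused ring system that carries either a trifluoromethyl group or two chlorine atoms. Compound 1 and compound 3 share one core, and compound 2 has the other. The difference between the two cores is not broken down here.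

One change has already been tested within the first core. Going from compound 1 to compound 3 means (nitro in place of hydroxy on an aromatic carbon), and in this assay this gave a 2.8-fold lower number from compound 1 to compound 3 (0.45 log units; beyond the scatter). The number of compound 2 lies within the usual scatter of both compound 1 and compound 3, so nothing can be said about its order relative to either.

Compound 4 `O=[N+]([O-])c1ccc(-c2nc3cc(Cl)c(Cl)cc3[nH]2)cc1` has not yet been measured. It stands to compound 2 as compound 3 stands to compound 1: the change is nitro in place of hydroxy on an aromatic carbon, and the surroundings of the place are described in the same words in both cases, so this is the same change made on the second core.

Because the earlier step was a 2.8-fold lower number from compound 1 to compound 3 (0.45 log units; beyond the scatter), the step from compound 2 to compound 4 is expected to be a 2.8-fold lower number from compound 2 to compound 4 (0.45 log units; beyond the scatter) in this assay. For compound 4 the expected value is therefore 4300 nM, estimated to fall between 2000 nM and 9000 nM.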

Compound 4, half-maximal cytotoxic concentration: 17000 nM
Compound 4: middle estimate off by 4.0-fold (0.60 log units), on the low side; measured number above the stated range.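

On the core of compound 2, putting nitro in place of hydroxy gives a 1.4-fold higher number from compound 2 to compound 4 (0.15 log units; within the scatter) in this assay, so the clear step seen on the core of compound 1 does not reappear on this second core. Set side by side, the two steps show that in this assay the effect of this change did not carry over from one core to the other, and that a step measured on one core was a poor guide to the same step on the other: the same change on two cores in this assay, a 2.8-fold lower number (0.45 log units; beyond the scatter) from compound 1 to compound 3 and a 1.4-fold higher number (0.15 log units; within the scatter) from compound 2 to compound 4, 4.0-fold (0.60 log units) apart, beyond the scatter of two such steps This comparison rests on only one pair of compounds per core, so it does not show why the two steps differ, nor how the same change would behave on any further core, and it cannot separate the role of the trifluoromethyl group from that of the two chlorine atoms, as these cores differ in both.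

The compounds shown leave open whether a core carrying a single chlorine atom would follow the core of compound 1 or that of compound 2. They also leave open how an amine or a carboxylic acid in place of the hydroxy would fare on each of the two cores.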